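This account rests on a few compounds, and the source may have more. Where it says the series, first, only, none or still open, it means among the compounds named here.

Working notes on the series. Within the data shown here, compound 2 `Cc1ccc(-c2cc(=O)c3ccc(C)cc3o2)cc1` holds the only number so far: in an in vitro assay on BTI-TN-5B1-4 cells for inhibition of Amine oxidase [flavin-containing] A (Homo sapiens), tested at 100 uM (a higher number here means more inhibition at the concentration tested (going by the name of the read-out), a lower number less inhibition), compound 2 gives 40%. Where compound 2 carries methyl in both places, compound 1 `O=c1cc(-c2ccc(F)cc2)oc2cc(F)ccc12` carries fluoro, and in this assay compound 1 is reported as "not active" (no number reported), without a number. Compound 3 `Cc1ccc(-c2cc(=O)c3ccc(F)cc3o2)cc1`, not yet measured, differs from compound 2 by fluoro in place of methyl on an aromatic carbon. Among the measured compounds shown here, no step between measured compounds is available; a fall beyond the scatter is expected, since compound 1 stands at "not active" (no number reported) in this assay with fluoro in that place. Compound 3 is expected at 25%, range 5% to 45%, an expected step of a number 15 percentage points lower from compound 2 to compound 3 (beyond the scatter).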

Compound 3, a percentage reported as inhibition, at one concentration (the size of the read-out at that concentration, not a potency): "not active" (no number reported)
The entry for compound 3 holds no number; there is nothing to compare the estimate with.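

Among these compounds, compound 3 carries no number, so no step from compound 2 to compound 3 can be read. The compounds shown leave open how much fluoro in place of methyl changes inhibition. No supporting evidence bears on this result.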